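A few compounds are considered here, and "the series" means these few. Any claim that something is new, unique, unknown or untested is made for them only; others in the source may bear on it.

Measured compounds:
compound 1 `Cn1cc(SCc2nnc(S)n2-c2c(Cl)cccc2Cl)c2ccccc21` — > 100000 nM
compound 2 `Cn1cc(SCc2nnc(SCc3ccccc3Cl)n2-c2c(Cl)cccc2Cl)c2ccccc21` — 49600 nM
compound 3 `Cn1cc(SCc2nnc(SCc3ccc(Cl)cc3Cl)n2-c2c(Cl)cccc2Cl)c2ccccc21` — > 100000 nM

In a toxicity assay on HEK-293T cells (Homo sapiens) for cytotoxicity, read by CCK-8 assay, with a stated time of 48 h (a higher number here means that more compound is tolerated, a lower number that less compound is tolerated), compound 1 gives > 100000 nM, which is a limit of the assay rather than a number. Among the measured compounds shown here, compound 2 gives 49600 nM in this assay, and that is the only number among the three values shown. Compound 3 gives > 100000 nM, again a limit. For the measured compounds named here, compound 2 therefore stands alone as the one compound with a measured number, while the other two sit at the limit of > 100000 nM in this assay, at which 2 of the 3 values shown sit.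

Compound 4 `Cn1cc(SCc2nnc(SCc3c(Cl)cccc3Cl)n2-c2c(Cl)cccc2Cl)c2ccccc21` differs from compound 2 by chloro in place of hydrogen on an aromatic carbon. Going by the values given here, two measured steps bear on this change. The closest is an at least 2.0-fold higher number from compound 2 to compound 3 (0.30 log units; that floor lies within the scatter), where a chloro added elsewhere on the benzyl ring moved the value back to the limit. The other is an at least 2.0-fold lower number from compound 1 to compound 2 (0.30 log units; that floor lies within the scatter), where the 2-chlorobenzyl group brought the value down from the limit to the only number shown. Both steps have a floor that lies within the scatter, so neither proves a real shift in this assay.

Given the step to compound 3, a further chloro on the benzyl ring is expected to give a step of a 1.6-fold higher number from compound 2 to compound 4 (0.21 log units; within the scatter) toward the limit, or none beyond the scatter. Compound 4 is thus estimated at 80000 nM, within 30000 nM to 200000 nM.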

Compound 4, half-maximal cytotoxic concentration: > 100000 nM
Compound 4: only a limit was reported; the forecaster's own chance of this, stated with the estimate: 45%; middle value at least 1.2-fold (0.09 log units) away from the limit.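

In this assay, among the compounds shown here, a second chloro on an aromatic carbon, ortho to a large group and meta to a chloro group, turns 2-chlorobenzyl into 2,6-dichlorobenzyl and gives an at least 2.0-fold higher number from compound 2 to compound 4 (0.30 log units; that floor lies within the scatter), so this position adds a second case to the one seen with compound 3, yet the floor of the step still does not establish a real shift. Compound 4 gives > 100000 nM, which is a limit of the assay and not a number, and the steps that link compound 4 to compound 1 and to compound 3 therefore cannot be read. For the compounds shown here, compound 2 remains the only compound with a number, and both dichlorobenzyl compounds, compound 3 and compound 4, now end at a limit, so these values do not separate the 2,4-dichlorobenzyl from the 2,6-dichlorobenzyl pattern: the limit of > 100000 nM in this assay, at which 3 of the 4 values shown sit.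

The compounds shown leave open whether compound 1, compound 3 and compound 4 differ from one another at all in this assay. They also leave open how a methoxy group or a carboxylic acid on the benzyl ring, or an amine or a longer chain on the sulfur in place of the benzyl group, would read there.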